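The compounds below may be only part of what the source reports. "The series", "measured", "known", "first", "only" and "open" are said of these compounds alone.

Three compounds share one core and differ only in the group attached to the carbonyl carbon next to the amide-type nitrogen. Compound 1 `CCN1CCN(c2cc(C)c3cc(NC(=O)c4ccccc4C)ccc3n2)CC1` carries a 2-methylphenyl there; in a functional assay on MCF7 cells (Homo sapiens) for antiproliferative activity, read by MTT assay, with a stated time of 72 h (a higher number here means a weaker inhibitor, a lower number a stronger inhibitor), compound 1 gives 10900 nM, the highest of the three numbers shown, although each of its steps to the other two lies within the scatter. Compound 2 `CCN1CCN(c2cc(C)c3cc(NC(=O)c4ccc(OC)cc4)ccc3n2)CC1` gives 7690 nM and compound 3 `CCN1CCN(c2cc(C)c3cc(NC(=O)c4cccc(F)c4)ccc3n2)CC1` gives 8920 nM. The steps of a 1.4-fold lower number from compound 1 to compound 2 (0.15 log units; within the scatter) and a 1.2-fold lower number from compound 1 to compound 3 (0.09 log units; within the scatter) show that exchanging the group on the carbonyl carbon has barely moved the number, and a 1.2-fold higher number from compound 2 to compound 3 (0.06 log units; within the scatter) is equally small.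

Compound 4 `CCN1CCN(c2cc(C)c3cc(NC(=O)c4ccco4)ccc3n2)CC1` brings in a different kind of ring: furan-2-yl in place of 2-methylphenyl on a carbonyl carbon. Among the compounds with values here, no measured step exchanges a six-membered aromatic ring for a five-membered one, so the three small steps are the only guide available. Because a 1.4-fold lower number from compound 1 to compound 2 (0.15 log units; within the scatter) and a 1.2-fold lower number from compound 1 to compound 3 (0.09 log units; within the scatter) both stayed within the scatter, compound 4 is expected to stay close to compound 1, with an expected step of a 1.1-fold lower number from compound 1 to compound 4 (0.06 log units; within the scatter). The estimate for compound 4 is 9500 nM, within a range from 4000 nM to 25000 nM.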

Compound 4, half-maximal inhibitory concentration: 41200 nM
Estimate against measurement, compound 4: 4.3-fold (0.64 log units) below, outside the stated range (above it).
By their numbers in this assay, from the lowest: compounds 2, 3 and 1 (each within the scatter of the next); then compound 4.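

The group on the carbonyl carbon is less indifferent than the first three compounds suggested: in this assay, furan-2-yl in place of the six-membered aromatic ring gives a 3.8-fold higher number from compound 1 to compound 4 (0.58 log units; beyond the scatter), and the same kind of exchange gives a 4.6-fold higher number from compound 3 to compound 4 (0.66 log units; beyond the scatter) and a 5.4-fold higher number from compound 2 to compound 4 (0.73 log units; beyond the scatter). All three steps lie beyond the scatter, whereas the exchanges among 2-methylphenyl, 3-fluorophenyl and 4-methoxyphenyl stayed within it, so among these four compounds only the change of ring moves the number clearly. Nothing measured here explains why the number rises with furan-2-yl.

On these data alone, whether the rise goes with the five-membered ring as such or with its oxygen stays open, and a thiophen-2-yl group, with sulfur in the ring, would speak to that. Also open, as far as these compounds go, is how a non-aromatic group, such as cyclopentyl, would behave on the same carbonyl carbon.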